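Amide versus urea on the anilide arm of the shared core

The source may report more compounds than this note shows. Statements on the series, on what has been measured and on what is new or still open speak of the compounds shown alone.

Compound 3 `COc1cc(-c2nn(-c3cccc(NC(=O)Nc4ccc(Cl)c(C(F)(F)F)c4)c3)cc2-c2ccncc2)ccc1Cl` carries a urea with (4-chloro-3-(trifluoromethyl)phenyl)amino on the carbonyl carbon. In a functional assay on Malme-3M cells (Homo sapiens) for inhibition, read by sulforhodamine B assay, with a stated time of 48 h (on this read-out lower numbers stand for higher toxicity in this test and higher numbers for lower toxicity in this test), compound 3 gives only a limit, > 32500 nM, so its place among the three measured values cannot be read off. Compound 2 `COc1cc(-c2nn(-c3cccc(NC(=O)Nc4cccc(C(F)(F)F)c4)c3)cc2-c2ccncc2)ccc1Cl` gives 33900 nM in this assay. Compound 1 `COc1cc(-c2nn(-c3cccc(NC(=O)c4cccc(C(F)(F)F)c4)c3)cc2-c2ccncc2)ccc1Cl` gives only a limit in this assay, > 50000 nM. The step from compound 2 to compound 3 is a step that the limit leaves unreadable from compound 2 to compound 3, and from compound 1 to compound 3 a step that the two limits leave unreadable from compound 1 to compound 3, both sitting at the limits the limit of > 32500 nM in this assay, at which 1 of the 3 values shown sits, and (the limit of > 50000 nM in this assay, at which 1 of the 3 values shown sits). Among the measured compounds shown here, the one readable step, an at least 1.4-fold lower number from compound 1 to compound 2 (0.16 log units; that floor lies within the scatter), stays within the scatter.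

Compound 4 `COc1cc(-c2nn(-c3cccc(NC(=O)c4ccccc4)c3)cc2-c2ccncc2)ccc1Cl` is the amide with plain phenyl on the carbonyl carbon: phenyl in place of (4-chloro-3-(trifluoromethyl)phenyl)amino on a carbonyl carbon. The nearest precedent is compound 1, itself an amide on this carbonyl, whose limit was given above; nothing among the measured steps reaches beyond the scatter. No step beyond the scatter is therefore expected, and the estimate for the move to compound 4 is a step that the limit leaves unreadable from compound 3 to compound 4. Compound 4 is expected to give about 60000 nM in this assay, most likely reported again as a limit, within a range of 30000 nM to 150000 nM.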

Compound 4, concentration lethal to 50% of the cells: > 100000 nM
Compound 4 ended at the assay's limit (the forecaster's own chance of this, stated with the estimate: 80%); at least 1.6-fold (0.22 log units) between middle value and limit.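

In this assay compound 4 is reported only as a limit of the assay: the limit of > 100000 nM in this assay, at which 1 of the 4 values shown sits. Among the compounds shown here, the one readable new step, an at least 2.9-fold higher number from compound 2 to compound 4 (0.46 log units; beyond the scatter), is the first to lie beyond the scatter, whereas the earlier readable step stayed within it; on this carbonyl carbon, phenyl in place of (3-(trifluoromethyl)phenyl)amino therefore moves the read-out towards lower toxicity in this test. The other two new steps cannot be read, so this single urea-to-amide comparison carries the finding, and it shows no pattern across the other compounds.

That one step removes the amino link of the urea and the trifluoromethyl together, and the compounds shown do not separate the two changes, nor do they show what the chloro of compound 3 contributes. Going by these compounds, how a carboxylic acid or a dimethylamino group on the phenyl ring of the amide would read in this assay also remains open.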